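The compounds below may be only part of what the source reports. "The series", "measured", "known", "first", "only" and "open" are said of these compounds alone.

Working notes on the series built on the shared core of compound 1 `Cc1ccc(-c2nc(SCc3cn(CC(=O)NC(=O)Nc4ccccn4)nn3)nc(Nc3ccc(C(C)C)cc3)c2C#N)cc1`. In a functional assay on MCF7 cells (Homo sapiens) for inhibition, read by MTT assay, with a stated time of 72 h (a lower number here means a stronger inhibitor, a higher number a weaker inhibitor), compound 1 gives only a limit, > 64000 nM, so where it stands among the numbers is known only as that limit (the limit of > 64000 nM in this assay, at which 1 of the 3 values shown sits). Compound 2 `Cc1ccc(-c2nc(SCc3cn(CC(=O)NC(=O)Nc4ccccn4)nn3)nc(Nc3cccc(Cl)c3)c2C#N)cc1` gives 14900 nM in this assay, and compound 3 `Cc1ccc(-c2nc(SCc3cn(CC(=O)NC(=O)Nc4ccccn4)nn3)nc(Nc3cccc(C(F)(F)F)c3)c2C#N)cc1` gives 6120 nM. All measured steps change the group on the nitrogen on the aromatic ring: an at least 4.2-fold lower number from compound 1 to compound 2 (0.63 log units; beyond the scatter); an at least 10-fold lower number from compound 1 to compound 3 (1.01 log units; beyond the scatter); a 2.4-fold lower number from compound 2 to compound 3 (0.39 log units; beyond the scatter). Compound 4 `CC(C)c1ccc(Nc2nc(SCc3cn(CC(=O)NC(=O)Nc4ccccn4)nn3)nc(-c3ccc(Br)cc3)c2C#N)cc1` differs from compound 1 in another part of the molecule: bromo in place of methyl on an aromatic carbon, while the 4-isopropylphenyl of compound 1 is kept. Going by the values given here, no measured step touches the 4-methylphenyl, so none of them bears on this change; the only anchor is that compound 1 sits at the limit. The step of a number no higher from compound 1 to compound 4 (the limit leaves the size open) is therefore expected to stay within the scatter, with a fair chance that compound 4 again returns only a limit. Compound 4 is estimated at 64000 nM in this assay, within 20000 nM to 200000 nM.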

Compound 4, half-maximal inhibitory concentration: 30600 nM
Estimate against measurement, compound 4: 2.1-fold (0.32 log units) above; measured number inside the range.
By their numbers in this assay, from the lowest: compound 3; then compound 2; then compound 4. At a limit, above all of these: compound 1.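

In this assay, going by these compounds alone, bromo in place of methyl gives an at least 2.0-fold lower number from compound 1 to compound 4 (0.32 log units; beyond the scatter), so the group on this aromatic carbon, para to a large group, also shifts the number; the earlier steps showed this only for the group on the nitrogen. With the 4-isopropylphenyl kept, compound 4 returns a number and not a limit, so that group does not by itself hold a compound at the limit. The full size of this step stays open because compound 1 gives only a limit: the limit of > 64000 nM in this assay, at which 1 of the 4 values shown sits.

On these data alone, whether the change from 4-methylphenyl to 4-bromophenyl carries over when the nitrogen bears 3-chlorophenyl or 3-(trifluoromethyl)phenyl remains open. Also open, as far as these compounds go, is how a methoxy group, an amine or a carboxylic acid on this same carbon would read in this assay.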